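Para-substituent swaps on a pyrazoline amine oxidase series

The compounds below may be only part of what the source reports. "The series", "measured", "known", "first", "only" and "open" are said of these compounds alone.

Measured so far:
compound 1 `CCC(=O)N1N=C(c2ccc(Cl)cc2)CC1c1ccc(Cl)cc1`: 200 nM
compound 2 `CCC(=O)N1N=C(c2ccc(F)cc2)CC1c1ccc(Cl)cc1`: 1410 nM
compound 3 `CCC(=O)N1N=C(c2ccc(OC)cc2)CC1c1ccc(Cl)cc1`: 832 nM

All three share one core and differ only in the group para to a large group on one phenyl ring. In an assay on isolated protein for inhibition of Amine oxidase [flavin-containing] A (Bos taurus) (a higher number here means a weaker inhibitor, a lower number a stronger inhibitor), the swap fluoro in place of chloro on an aromatic carbon gives a 7.1-fold higher number from compound 1 to compound 2 (0.85 log units; beyond the scatter), and the swap methoxy in place of chloro on an aromatic carbon gives a 4.2-fold higher number from compound 1 to compound 3 (0.62 log units; beyond the scatter). Between compound 2 and compound 3 the step of a 1.7-fold lower number from compound 2 to compound 3 (0.23 log units; within the scatter) is small, so no order is claimed between them.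

Compound 4 `CCC(=O)N1N=C(c2ccc(OC)cc2)CC1c1ccc(F)cc1` is not yet measured. It differs from compound 3 by fluoro in place of chloro on an aromatic carbon, the same change as from compound 1 to compound 2, made here on the core of compound 3, which differs from the core of compound 1 by methoxy in place of chloro on an aromatic carbon. Because a 7.1-fold higher number from compound 1 to compound 2 (0.85 log units; beyond the scatter) was beyond the scatter, a weakening of similar size is expected, tempered by the small gap a 1.7-fold lower number from compound 2 to compound 3 (0.23 log units; within the scatter). The expected step is a 4.2-fold higher number from compound 3 to compound 4 (0.62 log units; beyond the scatter). Compound 4 is estimated at 3500 nM in this assay, within 1200 nM to 10000 nM.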

Compound 4, half-maximal inhibitory concentration: 1000 nM
Compound 4: middle estimate off by 3.5-fold (0.54 log units), on the high side; the whole stated range lies above it.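

In this assay, fluoro in place of chloro on an aromatic carbon gives a 1.2-fold higher number from compound 3 to compound 4 (0.08 log units; within the scatter), so this swap does not carry over at one size between the two cores: the same change on two cores in this assay, a 7.1-fold higher number (0.85 log units; beyond the scatter) from compound 1 to compound 2 and a 1.2-fold higher number (0.08 log units; within the scatter) from compound 3 to compound 4, 5.9-fold (0.77 log units) apart, beyond the scatter of two such steps. The step seen on the core of compound 1 therefore cannot be applied as a fixed increment on the core of compound 3. Going by these compounds alone, this does not show why the steps differ: only two pairs are compared, and chloro leaves a different phenyl ring in each, so the effects of core and ring cannot be separated.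

As far as these compounds go, it remains open how an amine or a carboxylic acid on that aromatic carbon would compare with chloro. From the compounds shown here alone, whether either step would hold on further cores is also open.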